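Benzylamide of compound 1: expected cytotoxicity

This account rests on a few compounds, and the source may have more. Where it says the series, first, only, none or still open, it means among the compounds named here.

Compound 1 `CCCCn1cc(C(=O)O)c(=O)c2cc(F)c(N3CCC(C(N)=O)CC3)cc21` is the reference point of this small set. In an ADME assay on J774.1 cells (Mus musculus) for cytotoxicity, read by resazurin assay, with a stated time of 48 h (on this read-out higher numbers stand for weaker inhibition and lower numbers for stronger inhibition), compound 1 gives > 100000 nM, which is a limit of the assay and not a number. Compound 2 `NC(=O)C1CCN(c2cc3c(cc2F)c(=O)c(C(=O)O)cn3C2CC2)CC1` differs from compound 1 by cyclopropyl in place of butyl on an aromatic nitrogen. In this assay compound 2 gives > 100000 nM, again only a limit. The step that the two limits leave unreadable from compound 1 to compound 2 is therefore not readable. Compound 3 `CCCCn1cc(C(=O)O)c(=O)c2cc(F)c(N(C)Cc3ccccc3)cc21` carries benzyl(methyl)amino in place of 4-carbamoylpiperidin-1-yl on an aromatic carbon, and in this assay compound 3 gives 43200 nM. The step of an at least 2.3-fold lower number from compound 1 to compound 3 (0.36 log units; beyond the scatter) is the only readable one. Two of the three values sit at the limit of > 100000 nM in this assay, at which 2 of the 3 values shown sit, so compound 1 is known only by that limit.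

Compound 4 `CCCCn1cc(C(=O)NCc2ccccc2)c(=O)c2cc(F)c(N3CCC(C(N)=O)CC3)cc21` differs from compound 1 by benzylamino in place of hydroxy on a carbonyl carbon. Going by the values given here, neither measured step touches the carboxy group, so no step bears directly on this change; the one readable step, an at least 2.3-fold lower number from compound 1 to compound 3 (0.36 log units; beyond the scatter), shows a benzyl group entering at a different place on the core and the number falling. For compound 4 a modest lowering is expected, an at least 1.6-fold lower number from compound 1 to compound 4 (0.22 log units; that floor lies within the scatter), with a real chance that the assay again reports only a limit. The estimate for compound 4 is 60000 nM, expected to lie between 20000 nM and 150000 nM.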

Compound 4, half-maximal inhibitory concentration: 47000 nM
The estimate for compound 4 lay 1.3-fold (0.11 log units) above the measured number, and the stated range covers the measured number.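

In this assay, going by these compounds alone, the carbonyl carbon bearing the hydroxy group now enters the series for the first time, and replacing that hydroxy with benzylamino yields a readable step (an at least 2.1-fold lower number from compound 1 to compound 4 (0.32 log units; beyond the scatter)). The 4-carbamoylpiperidin-1-yl group stays in place here, so a measured number on the shared core does not depend on replacing that group, as it did in the earlier readable step (an at least 2.3-fold lower number from compound 1 to compound 3 (0.36 log units; beyond the scatter)). The new step has a floor and no exact size, since compound 1 is held by a limit of the assay and not by a number: the limit of > 100000 nM in this assay, at which 2 of the 4 values shown sit.

Going by these compounds, it remains open whether the lower number belongs to the benzyl ring or to the amide as such: a primary amide, a methylamide or a methyl ester on the same carbonyl carbon would separate the two. Also open, on these data alone, is whether the benzylamino and benzyl(methyl)amino changes add up on one core, and how either behaves with cyclopropyl on the aromatic nitrogen, where the step from compound 1 to compound 2 cannot be read between two limits.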